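Phenoxy for Butyl: Expected Cytotoxicity of Compound 4

The source may report more compounds than this note shows. Statements on the series, on what has been measured and on what is new or still open speak of the compounds shown alone.

Compound 1, `COC(=O)c1c[nH]c2cc(OCCOc3ccccc3)ccc2c1=O`, gives > 20000 nM in an ADME assay on J774 cells (Mus musculus) for cytotoxicity (on this read-out higher numbers stand for an effect only at larger amounts of compound and lower numbers for an effect already at smaller amounts), which is a limit of the assay and not a number.
Compound 2, `COC(=O)c1c[nH]c2cc(OCCOc3ccccc3)c(OC)cc2c1=O`, gives > 20000 nM in this assay, again a limit of the assay.
Compound 3, `CCCCc1ccc2[nH]cc(C(=O)OC)c(=O)c2c1`, gives > 20000 nM in this assay, also a limit of the assay.

All three measured compounds share one core, and every value recorded for them sits at the same limit: the limit of > 20000 nM in this assay, at which 3 of the 3 values shown sit. Compound 3 therefore stands at that limit together with the other two, and no order among the three can be read. Going by the values given here, the one step between measured compounds that differ in a single place, a step that the two limits leave unreadable from compound 1 to compound 2, cannot be read either, since both of its ends are limits.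

Compound 4, `COC(=O)c1c[nH]c2ccc(Oc3ccccc3)cc2c1=O`, has not yet been measured. It differs from compound 3 in one place: phenoxy in place of butyl on an aromatic carbon. Among the compounds with values here, no measured step involves this change, so nothing measured bears directly on it. Within the data shown here, with every value so far at the limit, the change is expected to give a step that the limit leaves unreadable from compound 3 to compound 4, none beyond the scatter. For compound 4 the estimate in this assay is 30000 nM, with a range from 15000 nM to 80000 nM, most likely reported once more only as a limit.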

Compound 4, half-maximal effective concentration: > 20000 nM
Compound 4 gave a limit, no number; the forecaster's own chance of this, stated with the estimate: 80%; the middle value lies beyond the limit too.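

No step can be read from compound 3 to compound 4, since both results are limits of the assay and not numbers, so phenoxy in place of butyl shows no readable effect: the limit of > 20000 nM in this assay, at which 4 of the 4 values shown sit.

The compounds shown leave open at what concentration any of the four would show an effect in this assay, and so whether they differ there at all.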